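The source may hold more compounds than are shown below. What is called first, only, known or untested is meant among the compounds shown, and "the series" means these compounds.

Measured in an ADME assay on L02 cells (Homo sapiens) for cytotoxicity, read by MTT assay, with a stated time of 48 h; on this read-out higher numbers stand for weaker inhibition and lower numbers for stronger inhibition:
- compound 1 `CCn1c(C(=O)NCCN(C)C)ccc1C(CC)(CC)c1ccc(OCC(=O)C(C)(C)C)c(C)c1`: 2500 nM
- compound 2 `CCN(CC)CCCNC(=O)c1ccc(C(CC)(CC)c2ccc(OCC(=O)C(C)(C)C)c(C)c2)n1CC`: 2300 nM
- compound 3 `CCOC(=O)CN(C)C(=O)c1ccc(C(CC)(CC)c2ccc(OCC(O)C(C)(C)C)c(C)c2)n1CC`: 10100 nM

Compound 3, at 10100 nM, has the highest number of the three, and its gaps to the other two lie beyond the scatter. The next compound to be tested is compound 4 `CCn1c(C(=O)NCCCN(C)C)ccc1C(CC)(CC)c1ccc(OCC(O)C(C)(C)C)c(C)c1`. Relative to compound 3, it carries (3-(dimethylamino)propyl)amino in place of ((ethoxycarbonyl)methyl)(methyl)amino on a carbonyl carbon.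

Going by the values given here, no measured step covers this exchange directly. Among the compounds with values here, the only step available is a 1.1-fold lower number from compound 1 to compound 2 (0.04 log units; within the scatter), which stays within the scatter. It suggests little sensitivity to the change at the amine end of the chain, but it rests on a single pair. Compound 1 and compound 2 both carry amine-ended amide chains, as compound 4 does. They sit close together, with compound 1 at 2500 nM and compound 2 at 2300 nM. However, their core differs from the one shared by compound 3 and compound 4, and the effect of that difference has not been measured separately. A move toward their values is therefore expected, but probably not all the way.

The expected change is a 2.9-fold lower number from compound 3 to compound 4 (0.46 log units; beyond the scatter), a lower number beyond the scatter.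

For compound 4 the estimated value is 3500 nM, with an expected range of 1500 nM to 8000 nM.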

Compound 4, half-maximal inhibitory concentration: 470 nM
Compound 4: the middle estimate sits 7.4-fold (0.87 log units) above what was measured, outside the stated range (below it).
By their numbers in this assay, from the lowest: compound 4; then compounds 2 and 1 (each within the scatter of the next); then compound 3.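

In this assay, the position on the carbonyl carbon proves highly sensitive to the group it carries: (3-(dimethylamino)propyl)amino in place of ((ethoxycarbonyl)methyl)(methyl)amino gives a 21-fold lower number from compound 3 to compound 4 (1.33 log units; beyond the scatter) on the shared core. The earlier pair showed only a change at the amine end of a chain that was already amine-ended, with a 1.1-fold lower number from compound 1 to compound 2 (0.04 log units; within the scatter), so it gave no sign of how much the whole group on the carbonyl carbon could matter.

The exchange alters several features at once: the ester is lost, the amide goes from 0 hydrogen-bond donors to 1, and a dimethylamino end enters, so this step cannot assign the gain to any one of them. Still open, on these data alone, is how a (3-(dimethylamino)propyl)(methyl)amino group, which keeps the amine but has no amide hydrogen, would compare with compound 4, and whether a 3-hydroxypropylamino chain or a carboxylic acid in place of the ethyl ester would shift the number in the same direction. Nothing available explains the size of this step.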